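The source may hold more compounds than are shown below. What is called first, only, known or untested is meant among the compounds shown, and "the series" means these compounds.

Going by the values given here, compound 1 `COc1cc(-c2nn(-c3cccc(NC(=O)Nc4ccc(Cl)c(Cl)c4)c3)cc2-c2ccncc2)ccc1Cl` gives 1720 nM in a functional assay on SNB-19 cells (Homo sapiens) for inhibition, read by sulforhodamine B assay, with a stated time of 48 h (a lower number here means a stronger inhibitor of growth, a higher number a weaker inhibitor of growth), the highest of the three numbers measured so far; compound 2 `O=C(Nc1cccc(-n2cc(-c3ccncc3)c(-c3ccc(Cl)c(O)c3)n2)c1)Nc1ccc(Cl)c(Cl)c1` gives 1460 nM and compound 3 `O=C(Nc1cccc(-n2cc(-c3ccncc3)c(-c3ccc(Cl)c(O)c3)n2)c1)Nc1cc(C(F)(F)F)cc(C(F)(F)F)c1` gives 983 nM, and both of these lie within the scatter of compound 1. Among the compounds with values here, the single step measured in one place, a 1.2-fold lower number from compound 1 to compound 2 (0.07 log units; within the scatter), stays within the scatter. Compound 4 `COc1cc(-c2nn(-c3cccc(NC(=O)c4ccccc4)c3)cc2-c2ccncc2)ccc1Cl` is the next point, reached from compound 1 by phenyl in place of (3,4-dichlorophenyl)amino on a carbonyl carbon. Within the data shown here, no measured step touches this part of the molecule: the one step measured, from compound 1 to compound 2, sits on the oxygen of the other aromatic ring, and the change from compound 2 to compound 3 concerns the substituents on the ring that now leaves, not its removal together with the amino group. Among the measured compounds shown here, the expectation for compound 4 therefore rests on no measured analogue and is given a wide range; compound 4 is estimated at 3500 nM in this assay, between 1000 nM and 12000 nM, meaning an expected step of a 2.0-fold higher number from compound 1 to compound 4 (0.31 log units; beyond the scatter).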

Compound 4, concentration for 50% growth inhibition: 860 nM
Estimate against measurement, compound 4: 4.1-fold (0.61 log units) above; measured number outside the range, below it.
By their numbers in this assay, from the lowest: compounds 4, 3, 2 and 1 (each within the scatter of the next).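

In this assay, phenyl in place of (3,4-dichlorophenyl)amino on a carbonyl carbon gives a 2.0-fold lower number from compound 1 to compound 4 (0.30 log units; within the scatter), so in this pair, dropping the nitrogen, both chlorine atoms and the hydrogen-bond donor of the leaving group leaves the number within the scatter. Going by these compounds alone, the earlier step, a 1.2-fold lower number from compound 1 to compound 2 (0.07 log units; within the scatter), sat on an oxygen on an aromatic ring, whereas this one gives the only reading at the carbonyl carbon and replaces the whole (3,4-dichlorophenyl)amino group. Nothing available on this pair accounts for the result.

Open, on these data alone, is whether the same replacement keeps the number within the scatter on compound 2, which carries hydrogen in place of methyl on that oxygen. Also open, as far as these compounds go, is how an amine, a carboxylic acid or a longer alkyl chain would read in place of phenyl on the carbonyl carbon.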